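A few compounds are considered here, and "the series" means these few. Any claim that something is new, unique, unknown or untested is made for them only; others in the source may bear on it.

Measured so far:
compound 1 `CC[C@H](C)[C@H](N)CN(C(=O)[C@@H]1C[C@H]1c1cccc(F)c1)c1ccc(-c2ccccc2)cc1` — 560 nM
compound 2 `CC(C)C[C@H](N)CN(C(=O)[C@@H]1C[C@H]1c1ccccc1)c1ccc(-c2ccccc2Cl)cc1` — 3800 nM
compound 3 `CCCc1ccc(-c2ccc(N(C[C@@H](N)[C@@H](C)CC)C(=O)[C@@H]3C[C@H]3c3ccccc3)cc2)cc1` — 61 nM

In a functional assay for agonist activity at G protein-coupled receptor 88 (Homo sapiens), read by HTRF and cAMP accumulation (a higher number here means that more compound is needed for the effect, a lower number that less compound is needed), compound 3 gives the lowest number of the three; its gap to compound 1 and its wider gap to compound 2 both lie beyond the scatter, so on these numbers compound 3 is the most potent of the set. Compound 4 `CC[C@H](C)[C@H](N)CN(C(=O)[C@@H]1C[C@H]1c1ccccc1)c1ccc(-c2ccc(N)cc2)cc1` is not yet measured. It differs from compound 3 in one place: amino in place of propyl on an aromatic carbon. Within the data shown here, no pair of measured compounds isolates this change, so nothing measured here shows how the 4-aminophenyl group compares with the 4-propylphenyl group. The expected change is a shift toward a higher number, beyond the scatter, of a 9.8-fold higher number from compound 3 to compound 4 (0.99 log units; beyond the scatter). Compound 4 is therefore estimated at 600 nM, within 150 nM to 2500 nM.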

Compound 4, half-maximal effective concentration: 320 nM
For compound 4 the middle estimate is 1.9-fold (0.27 log units) above the measured one, and the stated range covers the measured number.
By their numbers in this assay, from the lowest: compound 3; then compounds 4 and 1 (each within the scatter of the next); then compound 2.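

Among these compounds, on the aromatic carbon para to a large group, the change from 4-propylphenyl to 4-aminophenyl gives a 5.2-fold higher number from compound 3 to compound 4 (0.72 log units; beyond the scatter) in this assay and is the only isolated reading of this position. The position therefore responds to its substituent, and the propyl group gives the lower number of the two. Nothing available accounts for this shift.

Open, on these data alone, is whether the shift follows the shorter substituent or the amine itself, which a methyl or ethyl group would help separate. Also open, as far as these compounds go, is how a longer chain, such as butyl, would read here.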